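Ester to butylamide on the tetrazole side chain

The source may hold more compounds than are shown below. What is called first, only, known or untested is meant among the compounds shown, and "the series" means these compounds.

Three compounds share one core and differ only in the chain carried on the aromatic nitrogen. In an assay on isolated protein for displacement of a labelled ligand from growth hormone secretagogue receptor type 1 (Homo sapiens), with a stated time of 1 h (a higher number here means a weaker inhibitor, a lower number a stronger inhibitor), compound 1 `CC(C)(N)C(=O)N[C@H](COCc1ccccc1)c1nnnn1CCCc1ccccc1` gives 200 nM. Compound 2 `CC(C)(N)C(=O)N[C@H](COCc1ccccc1)c1nnnn1CCC#N` gives 2940 nM in this assay, and compound 3 `COC(=O)CCCn1nnnc1[C@@H](COCc1ccccc1)NC(=O)C(C)(C)N` gives 2380 nM. Compound 3 therefore stands second highest of the three numbers: its nearest neighbour is compound 2, since a 1.2-fold lower number from compound 2 to compound 3 (0.09 log units; within the scatter), while it lies furthest from compound 1, since a 12-fold higher number from compound 1 to compound 3 (1.08 log units; beyond the scatter).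

Compound 4 `CCCCNC(=O)CCn1nnnc1[C@@H](COCc1ccccc1)NC(=O)C(C)(C)N` has not been measured. It differs from compound 3 in one place: butylcarbamoyl in place of (methoxycarbonyl)methyl on a saturated chain carbon, two bonds along the chain from an aromatic nitrogen.

Which measured steps bear on this change? Both large steps lead to compound 1 and concern a phenyl on the chain: a 15-fold higher number from compound 1 to compound 2 (1.17 log units; beyond the scatter) and a 12-fold higher number from compound 1 to compound 3 (1.08 log units; beyond the scatter). For the measured compounds named here, the one step between two chains that carry no ring, a 1.2-fold lower number from compound 2 to compound 3 (0.09 log units; within the scatter), is within the scatter. Going by the values given here, the change to compound 4 keeps the chain free of any ring but brings in a butyl chain and an amide hydrogen that neither compound 2 nor compound 3 has, so there is no measured step of the same kind. She expects a modest shift toward a lower number, a 1.6-fold lower number from compound 3 to compound 4 (0.20 log units; within the scatter), with wide uncertainty. The estimate for compound 4 in this assay is 1500 nM, expected to lie between 400 nM and 5000 nM.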

Compound 4, inhibition constant: 2190 nM
The estimate for compound 4 lay 1.5-fold (0.16 log units) below the measured number; the range from low to high includes it.
By their numbers in this assay, from the lowest: compound 1; then compounds 4, 3 and 2 (each within the scatter of the next).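

In this assay, butylcarbamoyl in place of (methoxycarbonyl)methyl on a saturated chain carbon, two bonds along the chain from an aromatic nitrogen, gives a 1.1-fold lower number from compound 3 to compound 4 (0.04 log units; within the scatter), and butylcarbamoyl in place of cyano at the same place gives a 1.3-fold lower number from compound 2 to compound 4 (0.13 log units; within the scatter). Neither the longer chain nor the amide hydrogen therefore separates compound 4 from compound 2 or compound 3, so the three chains without a ring now cannot be told apart, while the only compound shown with a phenyl on the chain remains apart from them, with an 11-fold higher number from compound 1 to compound 4 (1.04 log units; beyond the scatter). No measurement is available that would account for this result.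

Going by these compounds, it remains open whether a phenyl ring at the end of the amide chain, as in a benzylamide, would bring the number back toward that of compound 1. Also open, on these data alone, is whether a carboxylic acid or a primary amine at the end of the chain, or a tertiary amide without the amide hydrogen, would stay with the chains that carry no ring.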